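Adding a Phenyl Ring to a Benzodiazepine-Like Amide Series

The compounds below may be only part of what the source reports. "The series", "measured", "known", "first", "only" and "open" are said of these compounds alone.

Three compounds have numbers in a functional assay on SK-OV-3 cells (Homo sapiens) for inhibition, read by sulforhodamine B assay, with a stated time of 72 h; on this read-out lower numbers stand for stronger inhibition of growth and higher numbers for weaker inhibition of growth. Compound 1 `CC(C)(C)OC(=O)NCCCCCN1C(Nc2ccc(-c3ccccc3)cc2)=Nc2ccccc2C1CC(=O)NCc1ccccc1` gives 2010 nM in this assay, compound 2 `CCN1C(N2CCCCC2)=Nc2ccccc2C1CC(=O)NCc1ccc(NS(=O)(=O)c2ccc(F)cc2)cc1` gives 26100 nM, and compound 3 `CC(C)(C)OC(=O)NCCCCCNC1=Nc2ccccc2C(CC(=O)NCc2ccccc2)N1c1ccccc1` gives 7180 nM. Compound 3 thus holds the second highest number of the three: compound 1 sits beyond the scatter on the lower side, and compound 2 beyond it on the higher side. Compound 4 `CC(C)(C)OC(=O)NCCCCCNC1=Nc2ccccc2C(CC(=O)NCc2ccccc2)N1c1ccc(-c2ccccc2)cc1` differs from compound 3 by phenyl in place of hydrogen on an aromatic carbon. For the measured compounds named here, no measured pair shows this change directly, so the step is uncertain. A small gain is expected, the step from compound 3 to compound 4 being estimated at a 1.8-fold lower number from compound 3 to compound 4 (0.25 log units; within the scatter), within the scatter. Compound 4 is estimated to give 4000 nM, between 1200 nM and 13000 nM.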

Compound 4, concentration for 50% growth inhibition: 1610 nM
Beside the measured number, compound 4's estimate is 2.5-fold (0.40 log units) above it; low and high end bracket the measured number.
By their numbers in this assay, from the lowest: compounds 4 and 1 (each within the scatter of the next); then compound 3; then compound 2.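

In this assay, phenyl in place of hydrogen on this aromatic carbon, para to a large group, gives a 4.5-fold lower number from compound 3 to compound 4 (0.65 log units; beyond the scatter). For the compounds shown here, this is the first comparison here of two compounds that differ in one place, and it shows that this position accepts a second aromatic ring with stronger growth inhibition. Nothing available bears on what lies behind this step. Still open, as far as these compounds go, is whether a smaller group here, such as methyl or fluorine, would also lower the number. Also open, from the compounds shown here alone, is whether an amine on the added ring would keep the gain.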